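Extending the ether chain of compound 2 by two carbons

The source may hold more compounds than are shown below. What is called first, only, known or untested is meant among the compounds shown, and "the series" means these compounds.

Measured compounds:
- compound 1 `CN(C)CCNc1ccnc2cc(OCc3ccc(F)cc3)ccc12`: 890 nM
- compound 2 `CCCCOc1ccc2c(Cl)ccnc2c1`: 3610 nM
- compound 3 `CN(C)CCNc1ccnc2cc(OCc3ccccc3)ccc12`: 1250 nM

In a functional assay on BGC-823 cells (Homo sapiens) for cytotoxicity, read by MTT assay, with a stated time of 48 h (a higher number here means a weaker inhibitor, a lower number a stronger inhibitor), compound 2 gives the highest of the three numbers. Its nearest neighbour is compound 3, which gives 1250 nM in this assay, a gap that lies beyond the scatter, and the gap to compound 1 is wider still. Compound 4 `CCCCCCOc1ccc2c(Cl)ccnc2c1` has not yet been measured. It differs from compound 2 by ethyl in place of hydrogen on a saturated chain carbon, four bonds along the chain from an oxygen on an aromatic ring, so the butoxy chain becomes a hexyloxy chain while the rest of the molecule is kept.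

Among the measured compounds shown here, only one step between measured compounds is available, a 1.4-fold higher number from compound 1 to compound 3 (0.15 log units; within the scatter), and it concerns a change on an aromatic carbon in a different series, so it says nothing about lengthening a saturated chain. For the measured compounds named here, no measured pair shows what two extra chain carbons do on the core of compound 2. With nothing to anchor a direction, the expected step is none beyond the scatter: compound 4 is estimated at 3000 nM in this assay, with a range from 1100 nM to 9000 nM, which means an expected step of a 1.2-fold lower number from compound 2 to compound 4 (0.08 log units; within the scatter).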

Compound 4, half-maximal inhibitory concentration: 2380 nM
For compound 4 the middle estimate is 1.3-fold (0.10 log units) above the measured one; measured number inside the range.
By their numbers in this assay, from the lowest: compounds 1, 3, 4 and 2 (each within the scatter of the next, the first and the last beyond it).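

Among the compounds shown here, the lengthening of the butoxy chain to a hexyloxy chain reads as a 1.5-fold lower number from compound 2 to compound 4 (0.18 log units; within the scatter) in this assay and is the first measured change at this position. Ethyl in place of hydrogen on a saturated chain carbon, four bonds along the chain from an oxygen on an aromatic ring, therefore leaves the number within the scatter on this core, which the earlier step, confined to an aromatic carbon in a different series, could not show. No supporting evidence bears on this result.

As far as these compounds go, whether a longer chain than hexyloxy, or a chain ending in an amine or a carboxylic acid, would shift the number beyond the scatter remains open. So does whether the same ethyl change would behave alike in the series of compound 1.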